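Swapping a benzoate ester for a carbamate on a triazole core

The source may report more compounds than this note shows. Statements on the series, on what has been measured and on what is new or still open speak of the compounds shown alone.

Of the compounds shown here, three built on a shared core have been tested in an assay on nucleic acid for inhibition of Nucleic Acid, read by fluorescence, tested at 100 uM; a lower number here means less inhibition, a higher number more inhibition at the concentration tested (going by the name of the read-out). Compound 1 `CN(Cc1cn(CC(O)COC(=O)NCc2ccccc2)nn1)CC1CCCCC1` gives 32% in this assay, compound 2 `CCCCN(CCCC)Cc1cn(CC(O)COC(=O)c2ccccc2)nn1` gives 12%, and compound 3 `CCOC(=O)C1CCCN(Cc2cn(CC(O)COC(=O)c3ccccc3)nn2)C1` gives 6%. Compound 3 stands lowest of the three numbers; its value sits within the usual scatter of that of compound 2, so the two cannot be ordered, while compound 1 lies clearly higher, beyond the scatter.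

Compound 4 `CCCCNC(=O)OCC(O)Cn1cc(CN2CCCC(C(=O)OCC)C2)nn1` has not yet been measured. It differs from compound 3 at one place: butylamino in place of phenyl on a carbonyl carbon. Read one bond further out, the benzoyl group becomes a butylcarbamoyl group. For the measured compounds named here, no measured pair shows this change on its own, so its effect is untested here.

Compound 1, the only carbamate among the measured compounds, carries the highest number, but it also differs elsewhere, so this gives only a weak hint. The step from compound 3 to compound 4 is expected to be small, a number 7 percentage points higher from compound 3 to compound 4 (within the scatter), at most a slight rise. Compound 4 is estimated to give 13%, within a range from 0% to 30%.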

Compound 4, a percentage reported as inhibition, at one concentration (the size of the read-out at that concentration, not a potency): 24%
Beside the measured number, compound 4's estimate is 11 percentage points below it; the measured number falls inside the stated range.
By their numbers in this assay, from the lowest: compounds 3 and 2 (each within the scatter of the next); then compounds 4 and 1 (each within the scatter of the next).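

In this assay, butylamino in place of phenyl on a carbonyl carbon now has a direct reading at this position: a number 18 percentage points higher from compound 3 to compound 4 (beyond the scatter), a modest rise. The earlier hint from compound 1, which differs from the others in more than one place, now has support from a pair that differs in one place only. Nothing available here explains why the number moves.

This swap changes two things at once, since a ring gives way to an open chain and a nitrogen with a hydrogen-bond donor enters, so the pair cannot show which change matters. On these data alone, a phenylamino group on the same carbonyl carbon, or a pentyl chain there, would help separate the two, and whether the step holds with other amines on the shared core remains open.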